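The compounds below may be only part of what the source reports. "The series", "measured", "known", "first", "only" and "open" are said of these compounds alone.

In an ADME assay on Jurkat cells (Homo sapiens) for cytotoxicity, read by trypan blue exclusion, with a stated time of 24 h (a lower number here means a stronger inhibitor, a higher number a weaker inhibitor), compound 1 `N#C[Se]Cc1ccc([N+](=O)[O-])cc1` gives 6860 nM and compound 2 `Cc1ccc(C[Se]C#N)cc1` gives 14400 nM, the highest of the two numbers. The next entry is compound 3 `N#C[Se]Cc1ccc(C#N)cc1`, with cyano in place of methyl on an aromatic carbon. For the measured compounds named here, one measured step bears on this change: a 2.1-fold higher number from compound 1 to compound 2 (0.32 log units; beyond the scatter), with methyl in place of nitro on an aromatic carbon. Here methyl leaves instead of entering, so a modest move to a lower number is expected in this assay. The expected step is a 1.7-fold lower number from compound 2 to compound 3 (0.23 log units; within the scatter). For compound 3 the estimated value is 8500 nM, within an expected range of 4500 nM to 15000 nM.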

Compound 3, half-maximal inhibitory concentration: 13400 nM
For compound 3 the middle estimate is 1.6-fold (0.20 log units) below the measured one; the measured number falls inside the stated range.
By their numbers in this assay, from the lowest: compounds 1, 3 and 2 (each within the scatter of the next, the first and the last beyond it).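

In this assay, cyano and methyl at this aromatic carbon cannot be told apart (a 1.1-fold lower number from compound 2 to compound 3 (0.03 log units; within the scatter)). Cyano in place of nitro also stays within the scatter (a 2.0-fold higher number from compound 1 to compound 3 (0.29 log units; within the scatter)), so the gap beyond the scatter is confined to the nitro and methyl pair, with cyano separated from neither. No available measurement accounts for these steps.

As far as these compounds go, whether an amine or a carboxylic acid at this aromatic carbon would stay within the same span remains open. From the compounds shown here alone, the effect of a longer chain in place of the methyl group is also open.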